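Replacing the Alkenyl Chain with Acetyl on the Shared Core

The compounds below may be only part of what the source reports. "The series", "measured", "known", "first", "only" and "open" are said of these compounds alone.

Compound 1, `Oc1nnc(-c2cccnc2)c2ccccc12`, gives 26% in an assay on isolated protein (Oryctolagus cuniculus) with Thromboxane-A synthase (Homo sapiens) as the target, tested at 1 uM; a higher number here means more inhibition at the concentration tested (going by the name of the read-out), a lower number less inhibition.
Compound 2, `CCCCCCCCn1nc(-c2cccnc2)c2ccccc2c1=O`, gives 99% in this assay.
Compound 3, `CC(C)=CCn1nc(-c2cccnc2)c2ccccc2c1=O`, gives 94% in this assay.

Compound 3 stands second highest of the three numbers; its value and that of compound 2 lie within the scatter of each other, while compound 1 sits far below both, beyond the scatter. Among the compounds with values here, the only measured step at this position, a number 5 percentage points lower from compound 2 to compound 3 (within the scatter), shows that exchanging one chain for another on the saturated chain carbon bound to the aromatic nitrogen left the read-out essentially unchanged.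

Compound 4, `CC(=O)Cn1nc(-c2cccnc2)c2ccccc2c1=O`, differs from compound 3 as follows: acetyl in place of 2-methylprop-1-en-1-yl on a saturated chain carbon bound to an aromatic nitrogen. Within the data shown here, no measured pair shows an acetyl group or any hydrogen-bond acceptor at this place, so the step from compound 2 to compound 3 bears on it only loosely. Because compound 1, with no chain at all, gives 26%, a shorter substituent carries some risk of a weaker read-out; the expected step is therefore a number 19 percentage points lower from compound 3 to compound 4 (beyond the scatter), a modest drop. Compound 4 is estimated at 75%, with a range from 45% to 95%.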

Compound 4, a percentage reported as inhibition, at one concentration (the size of the read-out at that concentration, not a potency): 13%
Compound 4: middle estimate off by 62 percentage points, on the high side; the whole stated range lies above it.
By their numbers in this assay, from the lowest: compound 4; then compound 1; then compounds 3 and 2 (each within the scatter of the next).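

Acetyl in place of 2-methylprop-1-en-1-yl on a saturated chain carbon bound to an aromatic nitrogen brings a number 81 percentage points lower from compound 3 to compound 4 (beyond the scatter) in this assay, and acetyl in place of heptyl brings a number 86 percentage points lower from compound 2 to compound 4 (beyond the scatter). The earlier compounds shown here showed two different chains giving values within the scatter of each other, whereas these large steps show that this place does not accept every group alike and that having a substituent there is not enough to keep the read-out high. No evidence at hand accounts for this loss.

The compounds shown leave open whether the drop goes with the carbonyl oxygen or with the shorter group, a question a propyl chain at this place would help to settle. They also leave open how an amine, a carboxylic acid or a ketone on a longer chain would read here.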